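Carbamoyl addition to the fluorophenyl amide

The source may hold more compounds than are shown below. What is called first, only, known or untested is meant among the compounds shown, and "the series" means these compounds.

Measured in an ADME assay on LLC-MK2 cells (Macaca mulatta) for cytotoxicity, read by spectrophotometry and crystal violet staining, with a stated time of 4 days; a lower number here means that less compound is tolerated, a higher number that more compound is tolerated:
- compound 1 `CC(C)n1ncc2c(C(=O)Nc3ccncc3)cc(-c3cccs3)nc21`: 6300 nM
- compound 2 `CC(C)n1ncc2c(C(=O)Nc3ccccc3F)cc(-c3cccs3)nc21`: 50000 nM

Of the two, compound 2 stands highest at 50000 nM. Compound 3 `CC(C)n1ncc2c(C(=O)Nc3cc(C(N)=O)ccc3F)cc(-c3cccs3)nc21` differs from it by carbamoyl in place of hydrogen on an aromatic carbon, the carbamoyl sitting para to a fluoro group. For the measured compounds named here, only one measured step bears on this: a 7.9-fold higher number from compound 1 to compound 2 (0.90 log units; beyond the scatter), a modest step that exchanged a different group on the same amide-type nitrogen. Going by the values given here, no measured compound carries a carbamoyl, so the direction is poorly supported, and no step beyond the scatter is expected in this assay. The expected change is a 1.7-fold lower number from compound 2 to compound 3 (0.22 log units; within the scatter). Compound 3 is estimated at 30000 nM, with a range of 10000 nM to 70000 nM.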

Compound 3, half-maximal cytotoxic concentration: 25000 nM
Compound 3: middle estimate off by 1.2-fold (0.08 log units), on the high side; measured number inside the range.
By their numbers in this assay, from the lowest: compound 1; then compounds 3 and 2 (each within the scatter of the next).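

In this assay, a carbamoyl on this aromatic carbon, para to a fluoro group, leaves the number within the scatter (a 2.0-fold lower number from compound 2 to compound 3 (0.30 log units; within the scatter)). The separation from the pyridin-4-yl amide remains with the larger 5-carbamoyl-2-fluorophenyl group in place (a 4.0-fold higher number from compound 1 to compound 3 (0.60 log units; beyond the scatter)). This first substitution on the 2-fluorophenyl ring therefore shows that the carbamoyl is tolerated here without a step beyond the scatter.

Open, from the compounds shown here alone, are a carboxylic acid, a nitrile or an aminomethyl at this same carbon, and a carbamoyl on the pyridin-4-yl ring. No measurement at hand explains these numbers.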